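Compound 2 and the (thiophen-2-yl)sulfonyl change

A few compounds are considered here, and "the series" means these few. Any claim that something is new, unique, unknown or untested is made for them only; others in the source may bear on it.

Values measured in a functional assay on HeLa cells (Homo sapiens) for antiproliferative activity, read by MTT assay, with a stated time of 48 h; a higher number here means a weaker inhibitor, a lower number a stronger inhibitor:
Compound 1 `Cn1cc(-c2cnc3ccnc(NC(=O)c4cccnc4)c3c2)cn1`: > 50000 nM (a limit)
Compound 2 `Cn1cc(-c2cnc3ccnc(NCC4CC4)c3c2)cn1`: 7400 nM
Compound 3 `COc1ccc(CNc2nccc3ncc(-c4cnn(C)c4)cc23)cc1`: 42200 nM

Compound 2 has the lower of the two actual numbers, since the entry for compound 1 is only a limit. The next compound, compound 4 `Cn1cc(-c2cnc3ccnc(NS(=O)(=O)c4cccs4)c3c2)cn1`, carries (thiophen-2-yl)sulfonyl in place of cyclopropylmethyl on a nitrogen on an aromatic ring. The closest measured change is an at least 6.7-fold lower number from compound 1 to compound 2 (0.82 log units; beyond the scatter), where cyclopropylmethyl replaced (pyridin-3-yl)carbonyl at that same nitrogen. The other, a 5.7-fold higher number from compound 2 to compound 3 (0.76 log units; beyond the scatter), also moved away from compound 2 toward a weaker result. Both point to a modest loss in this assay on leaving cyclopropylmethyl. The expected change is a 3.4-fold higher number from compound 2 to compound 4 (0.53 log units; beyond the scatter). For compound 4 the estimated value is 25000 nM, with an expected range from 9000 nM to 60000 nM.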

Compound 4, half-maximal inhibitory concentration: 17400 nM
Estimate against measurement, compound 4: 1.4-fold (0.16 log units) above, within the range that was stated.
By their numbers in this assay, from the lowest: compound 2; then compound 4; then compound 3. At a limit, above all of these: compound 1.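

In this assay, (thiophen-2-yl)sulfonyl in place of cyclopropylmethyl at this nitrogen gives a 2.4-fold higher number from compound 2 to compound 4 (0.37 log units; beyond the scatter), so a group bearing hydrogen-bond acceptors, which cyclopropylmethyl lacks, costs only a modest loss. Set against (pyridin-3-yl)carbonyl at the same nitrogen, the group gives an at least 2.8-fold lower number from compound 1 to compound 4 (0.45 log units; beyond the scatter), so a second non-alkyl group here now has a real reading. The entry for compound 1 is a limit, and that step has no exact size: the limit of > 50000 nM in this assay, at which 1 of the 4 values shown sits.

Whether the sulfonyl or the thiophene ring accounts for the loss stays open. So does whether methylsulfonyl, phenylsulfonyl or a longer alkyl chain at this nitrogen would match compound 2.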